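Lengthening the chain of compound 3

The compounds below may be only part of what the source reports. "The series", "measured", "known", "first", "only" and "open" are said of these compounds alone.

Among the compounds with values here, in a functional assay on MCF7 cells (Homo sapiens) for antiproliferative activity, read by MTT assay, with a stated time of 48 h (on this read-out higher numbers stand for weaker inhibition of growth and lower numbers for stronger inhibition of growth), compound 3 (`CCOc1cc(NC(=O)CCCCC(=O)Nc2ccccc2N)cc2c1OCC([N+](=O)[O-])=C2`) gives 17300 nM, the highest of the three numbers measured so far. Compound 2 (`CCOc1cc(NC(=O)CCCCC(=O)Nc2cc(-c3ccc(C)s3)ccc2N)cc2c1OCC([N+](=O)[O-])=C2`) gives 7910 nM and compound 1 (`CCOc1cc(NC(=O)CCCCCC(=O)Nc2cc(-c3ccccc3)ccc2N)cc2c1OCC([N+](=O)[O-])=C2`) gives 7030 nM, each lower than the number for compound 3 by more than the scatter.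

The next structure is compound 4 (`CCOc1cc(NC(=O)CCCCCC(=O)Nc2ccccc2N)cc2c1OCC([N+](=O)[O-])=C2`). The change is ((2-aminophenyl)carbamoyl)methyl in place of (2-aminophenyl)carbamoyl on a saturated chain carbon, four bonds along the chain from a carbonyl carbon, on a saturated chain carbon, four bonds along the chain from a carbonyl carbon.

Within the data shown here, the only measured single-place step is a 2.2-fold higher number from compound 2 to compound 3 (0.34 log units; beyond the scatter), a modest one. It concerns the loss of 5-methylthiophen-2-yl, not this chain, so it gives no direct size for the change. Compound 4 has the chain of compound 1 but differs from it elsewhere as well, so compound 1 with 7030 nM cannot isolate the chain effect. Among the measured compounds shown here, the data hold no measured pair that differs in chain length alone.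

With that gap, no step beyond the scatter is expected in this assay, and any drift may lean towards a lower number. The expected step is a 1.2-fold lower number from compound 3 to compound 4 (0.09 log units; within the scatter). For compound 4 the estimated value is 14000 nM, with an expected range from 7000 nM to 28000 nM.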

Compound 4, concentration for 50% growth inhibition: 19500 nM
Beside the measured number, compound 4's estimate is 1.4-fold (0.14 log units) below it, within the range that was stated.
By their numbers in this assay, from the lowest: compounds 1 and 2 (each within the scatter of the next); then compounds 3 and 4 (each within the scatter of the next).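

Working notes on the series: in this assay, ((2-aminophenyl)carbamoyl)methyl in place of (2-aminophenyl)carbamoyl on a saturated chain carbon, four bonds along the chain from a carbonyl carbon, gives a 1.1-fold higher number from compound 3 to compound 4 (0.05 log units; within the scatter), so this chain change alone shows no effect beyond the scatter in a pair that carries only hydrogen at the aromatic carbon. Hydrogen in place of phenyl on an aromatic carbon gives a 2.8-fold higher number from compound 1 to compound 4 (0.44 log units; beyond the scatter) on the longer chain, and this runs the same way as a 2.2-fold higher number from compound 2 to compound 3 (0.34 log units; beyond the scatter) on the shorter chain with 5-methylthiophen-2-yl, so in these four compounds the measured steps beyond the scatter sit at the aromatic substituent and not at the chain. The data shown hold nothing that explains either step.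

Still open, on these data alone, is whether the chain change stays within the scatter when phenyl or 5-methylthiophen-2-yl is present, as compound 1 and compound 2 differ in more than one place. Also open, as far as these compounds go, is how a still longer chain, or a pyridyl group in place of phenyl on the aromatic carbon, would read in this assay.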